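Pyrazin-2-yl in place of pyridin-3-yl on compound 2

This account rests on a few compounds, and the source may have more. Where it says the series, first, only, none or still open, it means among the compounds named here.

In a functional assay on L5178Y cells (Mus musculus) for cytotoxicity, read by MTT assay (on this read-out higher numbers stand for weaker inhibition and lower numbers for stronger inhibition), compound 1 (`CC(=O)c1ccc(OCCCCN2CCN(c3cccnc3)CC2)cc1`) gives 69 nM and compound 2 (`CCC(C)(C)c1ccc(OCCCCN2CCN(c3cccnc3)CC2)cc1`) gives 9.23 nM, the lower of the two numbers. Among the compounds with values here, the only measured step, a 7.5-fold lower number from compound 1 to compound 2 (0.87 log units; beyond the scatter), comes from 1,1-dimethylpropyl in place of acetyl on an aromatic carbon. Compound 3 (`CCC(C)(C)c1ccc(OCCCCN2CCN(c3cnccn3)CC2)cc1`) keeps the 1,1-dimethylpropyl group and differs from compound 2 elsewhere, with pyrazin-2-yl in place of pyridin-3-yl on an amine nitrogen in a ring. Within the data shown here, no measured step covers a change at this place, and the step from compound 1 to compound 2 gives no direct guide to its size or direction. Little or no movement beyond the scatter is therefore expected in this assay, with a slight lean towards a higher number. The expected change is a 1.3-fold higher number from compound 2 to compound 3 (0.11 log units; within the scatter). Compound 3 is estimated at 12 nM, with an expected range of 4 nM to 36 nM.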

Compound 3, half-maximal inhibitory concentration: 12.6 nM
For compound 3 the middle estimate is 1.1-fold (0.02 log units) below the measured one, and the stated range covers the measured number.
By their numbers in this assay, from the lowest: compounds 2 and 3 (each within the scatter of the next); then compound 1.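

In this assay the group on the amine nitrogen in a ring now has its first measured change, a 1.4-fold higher number from compound 2 to compound 3 (0.14 log units; within the scatter), so pyrazin-2-yl and pyridin-3-yl cannot be told apart on this read-out. The added ring nitrogen and the extra hydrogen-bond acceptor counted for pyrazin-2-yl thus bring no step beyond the scatter with 1,1-dimethylpropyl in place, whereas the earlier step concerned only the acetyl and 1,1-dimethylpropyl groups. No measured information is available to explain the size of this step.

Still open, going by these compounds, is whether phenyl, a ring without nitrogen, or a simple methyl on the same amine nitrogen would stay within the scatter of these values in this assay. Also open, on these data alone, is whether the same exchange gives as small a step with acetyl in place of 1,1-dimethylpropyl.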